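The source may hold more compounds than are shown below. What is called first, only, known or untested is meant among the compounds shown, and "the series" means these compounds.

Working notes, read-out in a physicochemical assay for solubility; on this read-out higher numbers stand for higher solubility and lower numbers for lower solubility
- compound 1 (`O=C(Nc1ccc(F)cc1)c1cc(Cl)ccc1O`) gives 1.6 ug/mL as a number
- compound 2 (`NS(=O)(=O)c1ccc(NC(=O)c2cc(Cl)ccc2O)cc1`) gives > 48 ug/mL as a limit, not a number
- compound 3 (`O=C(Nc1ccc(C(F)(F)F)cc1)c1cc(Cl)ccc1O`) is not yet measured

Compound 2 stands on (the limit of > 48 ug/mL in this assay, at which 1 of the 2 values shown sits), which is a limit and not a number, so any step from it starts from an open end.

The change to compound 3 is trifluoromethyl in place of sulfamoyl on an aromatic carbon, para to a large group (trifluoromethyl in place of sulfamoyl on an aromatic carbon).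

Going by the values given here, one measured step bears on this, sulfamoyl in place of fluoro on an aromatic carbon, with an at least 30-fold higher number from compound 1 to compound 2 (1.47 log units; beyond the scatter). That step is large and is itself bounded by a limit. Among the compounds with values here, compound 3 gives up the sulfamoyl that separates compound 2 from compound 1 (1.6 ug/mL), and no measured compound yet carries trifluoromethyl.

A large move to a lower number is therefore expected in this assay, of a size similar to the measured step. The expected step is an at least 48-fold lower number from compound 2 to compound 3 (1.68 log units; beyond the scatter). For compound 3 the estimate is 1 ug/mL, with an expected range from 0.3 ug/mL to 4 ug/mL.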

Compound 3, solubility: < 1 ug/mL
Compound 3 gave a limit, no number; the forecaster's own chance of this, stated with the estimate: 15%; the middle value sits exactly at the limit.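

In this assay, trifluoromethyl in place of sulfamoyl on an aromatic carbon, para to a large group, gives an at least 48-fold lower number from compound 2 to compound 3 (1.68 log units; beyond the scatter), so the high read-out of compound 2 does not carry over to a group of the same heavy-atom count without the sulfamoyl atoms. Trifluoromethyl in place of fluoro at the same carbon gives an at least 1.6-fold lower number from compound 1 to compound 3 (0.20 log units; that floor lies within the scatter), and since that floor lies within the scatter, the series so far shows no clear separation between these two compounds, both of which lack sulfamoyl and read far lower than compound 2. Compound 3 stands on a limit, not a number: the limit of < 1 ug/mL in this assay, at which 1 of the 3 values shown sits.

From the compounds shown here alone, compound 2 also stands on a limit, not a number, so the full size of the step between the two compounds stays open: the limit of > 48 ug/mL in this assay, at which 1 of the 3 values shown sits. Also open is whether the high read-out is tied to sulfamoyl itself or would also appear with another group on this carbon, such as a methyl sulfone, which keeps the sulfur and both oxygens without the nitrogen, or a carboxylic acid or an amine.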